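The source may hold more compounds than are shown below. What is called first, only, known or untested is meant among the compounds shown, and "the series" means these compounds.

Three compounds share one core and differ only in a single aromatic group. In an ADME assay on microsomes from liver (Homo sapiens) for metabolic stability (on this read-out higher numbers stand for fast clearance and lower numbers for slow clearance), compound 1 `CN1C(=O)C2=C(C1=O)N(CC(=O)Nc1ccc(-c3ccccc3)cc1)CCC2` gives 22 mL.min-1.g-1, compound 2 `CN1C(=O)C2=C(C1=O)N(CC(=O)Nc1ccc(-c3nccs3)cc1)CCC2` gives 24 mL.min-1.g-1, and compound 3 `CN1C(=O)C2=C(C1=O)N(CC(=O)Nc1ccc(-c3ccncc3)cc1)CCC2` gives 31 mL.min-1.g-1. Compound 3 therefore stands level with the other two, since both of its gaps lie within the usual scatter of repeated measurements.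

The next structure, compound 4 `CN1C(=O)C2=C(C1=O)N(CC(=O)Nc1ccc(-c3cccnc3)cc1)CCC2`, has the same atoms as compound 3, joined differently: pyridin-3-yl in place of pyridin-4-yl on an aromatic carbon. Here pyridin-3-yl takes the place of pyridin-4-yl on an aromatic carbon. For the measured compounds named here, no measured step makes this exact swap, so the closest evidence comes from the three exchanges at the same place. Pyridin-4-yl in place of phenyl gives a 1.4-fold higher number from compound 1 to compound 3 (0.15 log units; within the scatter), 1,3-thiazol-2-yl in place of phenyl gives a 1.1-fold higher number from compound 1 to compound 2 (0.04 log units; within the scatter), and pyridin-4-yl in place of 1,3-thiazol-2-yl gives a 1.3-fold higher number from compound 2 to compound 3 (0.11 log units; within the scatter). All three stay within the scatter, so no step beyond the scatter, in either direction, is expected in this assay for this smaller swap. The expected step is a 1.1-fold lower number from compound 3 to compound 4 (0.06 log units; within the scatter), an estimate that carries no real direction. For compound 4 the estimated value is 27 mL.min-1.g-1, with an expected range from 15 mL.min-1.g-1 to 48 mL.min-1.g-1.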

Compound 4, intrinsic clearance in microsomes: 37 mL.min-1.g-1
For compound 4 the middle estimate is 1.4-fold (0.14 log units) below the measured one; the range from low to high includes it.
By their numbers in this assay, from the lowest: compounds 1, 2, 3 and 4 (each within the scatter of the next).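

Swapping pyridin-4-yl for pyridin-3-yl, on an aromatic carbon para to a large group, gives no step that can be told from noise in this assay: the change is a 1.2-fold higher number from compound 3 to compound 4 (0.08 log units; within the scatter). Compound 4 also stays level with the other two compounds, with a 1.5-fold higher number from compound 2 to compound 4 (0.19 log units; within the scatter) and a 1.7-fold higher number from compound 1 to compound 4 (0.23 log units; within the scatter), so phenyl, 1,3-thiazol-2-yl, pyridin-4-yl and pyridin-3-yl all give numbers within the scatter of one another at this place. Nothing measured here offers a cause for this flat result.

As far as these compounds go, what stays open is whether a group of a different kind at this place, such as a carboxylic acid, an amine, or a plain methyl standing in for the whole aromatic ring, would shift the number beyond the scatter. Equally open, from the compounds shown here alone, is whether a change away from this place, such as a longer chain on the shared core, would matter more than any of these aromatic exchanges.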